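The compounds below may be only part of what the source reports. "The series", "measured", "known", "first", "only" and "open" are said of these compounds alone.

Two biphenyl compounds have been measured in a functional assay on HT-29 cells (Homo sapiens) for cytotoxicity, read by MTT assay, with a stated time of 3 days; a higher number here means a weaker inhibitor, a lower number a stronger inhibitor. Compound 1, with the structure `COc1ccccc1-c1ccccc1O`, gives 2.7 ug/mL in this assay. Compound 2, with the structure `COc1ccccc1-c1cccc(O)c1`, gives 22 ug/mL in this assay. Of these two numbers, compound 2 holds the higher one, and the gap down to compound 1 is beyond the usual scatter, so compound 1 is the stronger inhibitor of the pair. The next compound, compound 3, has the structure `Nc1ccccc1-c1cccc(O)c1` and is still to be measured. It differs from compound 2 in one place: amino in place of methoxy on an aromatic carbon. Among the compounds with values here, no measured pair shows the effect of this exchange, so there is nothing to scale a step from. The step from compound 2 to compound 3 is therefore expected to stay within the scatter, as a 1.1-fold lower number from compound 2 to compound 3 (0.04 log units; within the scatter). Compound 3 is estimated at 20 ug/mL, with a range from 8 ug/mL to 50 ug/mL.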

Compound 3, half-maximal inhibitory concentration: 9.2 ug/mL
Beside the measured number, compound 3's estimate is 2.2-fold (0.34 log units) above it; the range from low to high includes it.
By their numbers in this assay, from the lowest: compound 1; then compound 3; then compound 2.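

In this assay, putting amino in place of methoxy on this aromatic carbon gives a 2.4-fold lower number from compound 2 to compound 3 (0.38 log units; beyond the scatter), a modest step but a real one. Within the data shown here, this is the first measured pair with a single change at this position, ortho to a group of 7 heavy atoms, and it shows that the number responds to the group placed there. The exchange removes one heavy atom and adds one hydrogen-bond donor, but no measurement here links either difference to the step, and nothing else available accounts for it.

The compounds shown leave open whether a methyl, dimethylamino or acetamido group on the same carbon would lower the number further or raise it. A single pair also cannot tell whether the same exchange would give a similar step on the core of compound 1.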